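One Stereocentre Inverted at a Ring Carbon

The compounds below may be only part of what the source reports. "The series", "measured", "known", "first", "only" and "open" are said of these compounds alone.

Compound 1 `CC(=O)CC/C=C(\C)CCC1=C(C)CCCC1(C)C` in a functional assay on MDA-MB-435 cells (Homo sapiens) for inhibition (on this read-out lower numbers stand for stronger inhibition of growth and higher numbers for weaker inhibition of growth), gives > 15000 nM, which is a limit of the assay rather than a number.
Compound 2 `C=C1CCC[C@H]2[C@](C)(CC[C@]3(C)CC[C@@H]([C@@H](C)C(=O)O)OO3)[C@@H](C)CC[C@]12C` gives 2060 nM.
Compound 3 `C=C1CCCC(C)(C)C1(O)CC/C(C)=C/CC[C@]1(C)CC[C@@H]([C@@H](C)C(=O)OC)OO1` gives > 17500 nM, again a limit and not a number.

Of the three measured compounds, compound 2 is the only one for which the assay returned an actual figure. Compound 1 sits at the limit of > 15000 nM in this assay, at which 1 of the 3 values shown sits. Compound 3 sits at the limit of > 17500 nM in this assay, at which 1 of the 3 values shown sits. Going by the values given here, no step between two measured compounds that differ in a single place is available, so the scatter of this assay is the only guide to what a small change may do.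

Compound 4 `C=C1CCC[C@H]2[C@](C)(CC[C@]3(C)CC[C@H]([C@@H](C)C(=O)O)OO3)[C@@H](C)CC[C@]12C` is the next compound to be tested. Compared with compound 2, (the two compounds have the same atoms and bonds and differ only in configuration as drawn: 1 of 7 stereo elements differ; a stereocentre at a saturated ring carbon is drawn S in compound 2 and R in compound 4). Inverting one stereocentre while keeping every atom and bond can leave the result within the usual scatter or shift it noticeably, and nothing among the measured compounds shows which. The expected step from compound 2 to compound 4 is a 1.7-fold higher number from compound 2 to compound 4 (0.23 log units; within the scatter), a mild move toward weaker inhibition with wide uncertainty. Compound 4 is therefore estimated at 3500 nM, within a range of 1000 nM to 12000 nM.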

Compound 4, concentration for 50% growth inhibition: 1980 nM
The estimate for compound 4 lay 1.8-fold (0.25 log units) above the measured number; the range from low to high includes it.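

In this assay, going by these compounds alone, inverting the stereocentre at the saturated ring carbon gives a 1.0-fold lower number from compound 2 to compound 4 (0.02 log units; within the scatter), the first step between two compounds that differ in one place. The earlier compounds could not show how much this position matters, for no two of them formed such a pair; here, the number does not respond to whether this ring carbon is drawn S or R. The comparison speaks to configuration alone, since nothing enters or leaves: the fact that compounds 2 and 4 differ only in the configuration as drawn

Going by these compounds, whether the result would hold with an amide in place of the carboxylic acid remains open. Also open, on these data alone, is whether inverting any of the other stereocentres would leave the number equally undisturbed.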